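The compounds below may be only part of what the source reports. "The series", "measured", "known", "first", "only" and "open" are said of these compounds alone.

Measured so far:
compound 1, `O=C(S[C@]12CC[C@@H](O)[C@H]1C(=O)NC2=O)c1ccc(O)cc1`: 616000 nM
compound 2, `O=C(S[C@]12CC[C@H](O)[C@H]1C(=O)NC2=O)c1ccc(O)cc1`: 1380000 nM
Not yet measured: compound 3, `O=C(S[C@]12CC[C@H](O)[C@H]1C(=O)NC2=O)c1ccccc1`.

In an ADME assay on RAW264.7 cells (Mus musculus) for cytotoxicity, read by MTT assay, with a stated time of 24 h (on this read-out higher numbers stand for weaker inhibition and lower numbers for stronger inhibition), compound 1 gives 616000 nM and compound 2 gives 1380000 nM. Compound 2 thus holds the highest of the two numbers, with compound 1 as its nearest neighbour, a step below it that lies beyond the scatter. Within the data shown here, the only measured step is a 2.2-fold higher number from compound 1 to compound 2 (0.35 log units; beyond the scatter), and it rests on (the fact that compounds 1 and 2 differ only in the configuration as drawn); it involves no change of substituents at all. Compound 3 is compound 2 with the change (hydrogen in place of hydroxy on an aromatic carbon), which cut one bond further out reads 4-hydroxyphenyl to phenyl. Among the measured compounds shown here, no measured step touches this part of the molecule, so nothing measured bears directly on the change; the two numbers so far only show that the series sits at very high concentrations in this assay. A step no larger than the scatter is therefore expected in this assay, in no particular direction. The expected step is thus a 1.2-fold lower number from compound 2 to compound 3 (0.06 log units; within the scatter). For compound 3 the estimate is 1200000 nM, with a range from 450000 nM to 3200000 nM.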

Compound 3, half-maximal inhibitory concentration: 17100000 nM
Estimate against measurement, compound 3: 14-fold (1.15 log units) below, outside the stated range (above it).
By their numbers in this assay, from the lowest: compound 1; then compound 2; then compound 3.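

In this assay, among these compounds, hydrogen in place of hydroxy on the aromatic ring, para to a large group, gives a 12-fold higher number from compound 2 to compound 3 (1.09 log units; beyond the scatter), the first evidence that the number depends strongly on this position. Among the compounds shown here, this step is much larger than a 2.2-fold higher number from compound 1 to compound 2 (0.35 log units; beyond the scatter), so within these three compounds the 4-hydroxyphenyl to phenyl change moves the read-out further than the single change of configuration, and in the direction of weaker inhibition. Nothing at hand explains why the loss of this hydroxy has so large an effect.

From the compounds shown here alone, the result comes from one pair on the configuration of compound 2, so it remains open whether the same change on the configuration of compound 1 would give a step of similar size. Also open, going by these compounds, is whether the large step depends on the hydroxy itself, which a methoxy group, an amine or a fluorine atom at the same place would help to show, and whether moving the hydroxy elsewhere on the aromatic ring would have a comparable effect.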